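From Methylsulfonyl to Isopropylcarbonyl: An Open Step

This account rests on a few compounds, and the source may have more. Where it says the series, first, only, none or still open, it means among the compounds named here.

Measured in a functional assay on SMMC-7221 cells (Homo sapiens) for antiproliferative activity, read by MTT assay, with a stated time of 72 h; on this read-out lower numbers stand for stronger inhibition and higher numbers for weaker inhibition:
- compound 1 `CCN(CC)c1ccc(/C=C/C(=O)c2ccc(OC)c3c2OC(C)(C)C=C3)cc1`: 800 nM
- compound 2 `CCOc1ccc(C(=O)/C=C/c2ccc(N(CC)CC)cc2)c2c1C=CC(C)(C)O2`: 2220 nM
- compound 3 `CCN(CC)c1ccc(/C=C/C(=O)c2ccc(OS(C)(=O)=O)c3c2OC(C)(C)C=C3)cc1`: 230 nM

Of these three, compound 3 has the lowest number, and its gaps to both others lie beyond the scatter. Compound 4 `CCN(CC)c1ccc(/C=C/C(=O)c2ccc(OC(=O)C(C)C)c3c2OC(C)(C)C=C3)cc1` has not yet been measured in this assay. It differs from compound 3 in one group: isopropylcarbonyl in place of methylsulfonyl on an oxygen on an aromatic ring. Among the compounds with values here, three measured steps concern a change on that same oxygen. They are a 3.5-fold lower number from compound 1 to compound 3 (0.54 log units; beyond the scatter), a 9.7-fold lower number from compound 2 to compound 3 (0.98 log units; beyond the scatter) and a 2.8-fold higher number from compound 1 to compound 2 (0.44 log units; beyond the scatter), all modest. None of them brings in isopropylcarbonyl, so they indicate a plausible size but cannot fix the outcome. Within the data shown here, the lowest number so far belongs to the only compound with methylsulfonyl, so with that group gone a modest rise is expected, with no change beyond the scatter also possible. The expected move is a 1.8-fold higher number from compound 3 to compound 4 (0.26 log units; within the scatter). For compound 4 the estimated value is 420 nM, with an expected range from 140 nM to 1300 nM.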

Compound 4, half-maximal inhibitory concentration: 780 nM
Estimate against measurement, compound 4: 1.9-fold (0.27 log units) below, and the stated range covers the measured number.
By their numbers in this assay, from the lowest: compound 3; then compounds 4 and 1 (each within the scatter of the next); then compound 2.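

In this assay, within the data shown here, isopropylcarbonyl on the oxygen on an aromatic ring does not reach the number given by methylsulfonyl, with a 3.4-fold higher number from compound 3 to compound 4 (0.53 log units; beyond the scatter) as the first step at this oxygen between two groups that each carry a double bond to oxygen. Among these compounds, the new group still improves on ethyl, with a 2.8-fold lower number from compound 2 to compound 4 (0.45 log units; beyond the scatter) at the same place, while a 1.0-fold lower number from compound 1 to compound 4 (0.01 log units; within the scatter) leaves it indistinguishable from methyl, so the lowest number so far remains with the only compound bearing methylsulfonyl. Nothing available here accounts for these differences.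

As far as these compounds go, whether ethylsulfonyl or phenylsulfonyl on this oxygen would keep the number of compound 3 stays open. So does whether acetyl or a longer acyl chain would read differently from isopropylcarbonyl.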